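This account rests on a few compounds, and the source may have more. Where it says the series, first, only, none or still open, it means among the compounds named here.

Measured so far:
- compound 1, `CC(=O)N[C@@H]1CCC[C@H](C(=O)Nc2cc(-c3cnn4c3CCCC4)c(Cl)cn2)C1`: 46 uL/min
- compound 2, `CC(=O)N[C@@H]1CCC[C@H](C(=O)Nc2cc(-c3cnn(C)c3C)c(Cl)cn2)C1`: 10 uL/min
- compound 3, `CC(=O)N[C@@H]1CCC[C@H](C(=O)Nc2cc(-c3cnc4n3CCCC4)c(Cl)cn2)C1`: 12 uL/min

These three compounds share one core and differ only in the group attached on an aromatic carbon of the core, and all were tested in an ADME assay on cells (Hepatocyte, Rattus norvegicus) for metabolic stability, using equilibrium dialysis; a higher number here means faster removal of the compound, a lower number slower removal. Compound 3 sits second highest of the three numbers: its value is within the scatter of compound 2, and compound 1 stands a clear distance above it, as the step of a 3.8-fold lower number from compound 1 to compound 3 (0.58 log units; beyond the scatter) shows. The step of a 4.6-fold lower number from compound 1 to compound 2 (0.66 log units; beyond the scatter) is of similar size, while a 1.2-fold higher number from compound 2 to compound 3 (0.08 log units; within the scatter) shows no real difference.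

Compound 4, `CC(=O)N[C@@H]1CCC[C@H](C(=O)Nc2cc(-c3cnn4c3CCC4)c(Cl)cn2)C1`, is not yet measured. It differs from compound 3 in one place: a group of 8 heavy atoms (6 carbon, 2 nitrogen; one five-membered non-aromatic ring with 1 hetero atom, one five-membered aromatic ring with 2 hetero atoms) in place of a group of 9 heavy atoms (7 carbon, 2 nitrogen; one five-membered aromatic ring with 2 hetero atoms, one six-membered non-aromatic ring with 1 hetero atom), on an aromatic carbon. Among the compounds with values here, the measured steps show that changing the fused group on this carbon can move the number beyond the scatter, but none of them exchanges a six-membered non-aromatic ring for a five-membered one, so there is no direct precedent. A modest rise toward compound 1 is plausible but uncertain; a step of a 1.7-fold higher number from compound 3 to compound 4 (0.22 log units; within the scatter) is expected, which may stay within the scatter. For compound 4 the estimate in this assay is 20 uL/min, with a likely range from 8 uL/min to 50 uL/min.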

Compound 4, intrinsic clearance in a liver preparation (reported as CLH), per the amount of preparation that the assay uses: 72 uL/min
Compound 4: middle estimate off by 3.6-fold (0.56 log units), on the low side, and the stated range ends below it.
By their numbers in this assay, from the lowest: compounds 2 and 3 (each within the scatter of the next); then compounds 1 and 4 (each within the scatter of the next).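

In this assay, the size of the non-aromatic ring alone makes no real difference when the rest of the fused group stays as it is in compound 1 (a 1.6-fold higher number from compound 1 to compound 4 (0.19 log units; within the scatter)). Compound 4 instead stands clearly apart from the two other compounds (a 6.0-fold higher number from compound 3 to compound 4 (0.78 log units; beyond the scatter) and a 7.2-fold higher number from compound 2 to compound 4 (0.86 log units; beyond the scatter)), so this position now shows two clusters with two compounds in each. Compounds 1 and 4 share one placement of the nitrogens in the five-membered aromatic ring, with the non-aromatic ring closed onto it, whereas compound 2 keeps that placement with two separate methyl groups and compound 3 keeps a fused ring with its nitrogens placed differently, so neither the fused ring nor the nitrogen placement alone goes with the higher numbers.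

Nothing available here explains why the compounds split this way. From the compounds shown here alone, it also remains open where a seven-membered non-aromatic ring, or an oxygen atom in place of a carbon in the five-membered non-aromatic ring, would fall in these two clusters.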